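The source may report more compounds than this note shows. Statements on the series, on what has been measured and on what is new or still open speak of the compounds shown alone.

Working notes on the series, read in an ADME assay on the whole organism (plasma, Rattus norvegicus) for protein binding, using cassette dosing, at a dose of 1 mg/kg; a higher number here means a larger unbound share of the compound, a lower number a smaller unbound share. Compound 1 `Cc1cc(/N=c2\[nH]c(=O)n(C[C@H](C)C(=O)O)c(=O)n2Cc2ccc(Cl)cc2)ccc1OC(C)C` gives 0.02, compound 2 `C[C@@H](Cn1c(=O)[nH]/c(=N\c2ccc(Oc3nccs3)cc2)n(Cc2ccc(Cl)cc2)c1=O)C(=O)O` gives 0.006 and compound 3 `CC(C)Oc1ccc(/N=c2\[nH]c(=O)n(CC(C)(C)C(=O)O)c(=O)n2Cc2ccc(Cl)cc2)cc1Cl` gives 0.003. Compound 2 stands with compound 3 at the low end of these numbers, the two lying within the scatter of each other, while compound 1 stands above both, beyond the scatter. Among the measured compounds shown here, no two measured compounds differ in one place only, so the series offers no direct step to draw on.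

Compound 4 `C[C@@H](Cn1c(=O)[nH]/c(=N\c2ccc(Oc3ccsn3)cc2)n(Cc2ccc(Cl)cc2)c1=O)C(=O)O` is still unmeasured. It has the same atoms as compound 2, joined differently, with 1,2-thiazol-3-yl in place of 1,3-thiazol-2-yl on an oxygen on an aromatic ring. No step beyond the scatter is expected in this assay, and no direction is favoured. The estimated change is no change at the digits printed from compound 2 to compound 4 (within the scatter). The expectation therefore rests on compound 2 at 0.006. The expected value for compound 4 is 0.006, with an estimated range of 0.003 to 0.013.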

Compound 4, unbound fraction: 0.012
Compound 4: middle estimate off by 2.0-fold (0.30 log units), on the low side; the range from low to high includes it.
By their numbers in this assay, from the lowest: compounds 3, 2, 4 and 1 (each within the scatter of the next, the first and the last beyond it).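

Among the compounds shown here, the step of 1,2-thiazol-3-yl in place of 1,3-thiazol-2-yl on an oxygen on an aromatic ring, a 2.0-fold higher number from compound 2 to compound 4 (0.30 log units; within the scatter), is the first single-place comparison in this assay. At this position, rearranging the atoms of the ring while keeping the same atoms and the same counted donors and acceptors leaves the unbound fraction within the scatter, so no direction can be assigned to the change. No measurement at hand bears on why the two compounds read as they do.

Still open, going by these compounds, is whether a different ring on that oxygen, such as pyridin-2-yl or phenyl, would give a step beyond the scatter. For the compounds shown here, also open is how a primary amide in place of the carboxylic acid would read, as no single-place step addresses that end of the molecule.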